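The source may hold more compounds than are shown below. What is called first, only, known or untested is meant among the compounds shown, and "the series" means these compounds.

Measured in a functional assay on HEL cells (Homo sapiens); on this read-out lower numbers stand for higher toxicity in this test and higher numbers for lower toxicity in this test:
- Compound 1 `C=C(C)C(=O)NC(=O)NC1=CS(=O)(=O)O[C@@]12[C@@H](CO[Si](C)(C)C(C)(C)C)O[C@@H](n1cc(C)c(=O)n(C)c1=O)[C@@H]2O[Si](C)(C)C(C)(C)C`: 1200 nM
- Compound 2 `CCOC(=O)CNC(=O)NC1=CS(=O)(=O)O[C@@]12[C@@H](CO[Si](C)(C)C(C)(C)C)O[C@@H](n1cc(C)c(=O)n(C)c1=O)[C@@H]2O[Si](C)(C)C(C)(C)C`: 13000 nM
- Compound 3 `COC(=O)C(=O)CNC1=CS(=O)(=O)O[C@@]12[C@@H](CO[Si](C)(C)C(C)(C)C)O[C@@H](n1cc(C)c(=O)n(C)c1=O)[C@@H]2O[Si](C)(C)C(C)(C)C`: > 200000 nM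

Compound 3 gives > 200000 nM, and this is a limit of the assay, not a number. Compound 4 `Cc1cn([C@@H]2O[C@H](CO[Si](C)(C)C(C)(C)C)[C@@]3(OS(=O)(=O)C=C3NC(=O)NC(=O)c3ccccc3)[C@H]2O[Si](C)(C)C(C)(C)C)c(=O)n(C)c1=O` has not yet been measured. It departs from compound 3 as follows: benzoylcarbamoyl in place of ((methoxycarbonyl)carbonyl)methyl on an amine nitrogen. In words, benzoylcarbamoyl takes the place of ((methoxycarbonyl)carbonyl)methyl on an amine nitrogen.

Two measured steps arrive at that same leaving group, and both are large: an at least 160-fold higher number from compound 1 to compound 3 (2.22 log units; beyond the scatter), and an at least 15-fold higher number from compound 2 to compound 3 (1.18 log units; beyond the scatter). Both compound 1 and compound 2 carry a carbamoyl group on this nitrogen, so the change to compound 4 is expected to run the opposite way, towards lower numbers and higher toxicity. The substituent on the carbamoyl also counts, as shown by an 11-fold higher number from compound 1 to compound 2 (1.03 log units; beyond the scatter). Compound 1, with 1200 nM, is taken as the closer guide, since its ((1-methylethenyl)carbonyl)carbamoyl also ends in a carbonyl, as benzoylcarbamoyl does. Within the data shown here, no measured compound carries a benzoyl group, so the range is kept wide.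

The expected change is an at least 100-fold lower number from compound 3 to compound 4 (2.00 log units; beyond the scatter), a large step beyond the scatter. For compound 4 the estimated value is 2000 nM, with an expected range of 400 nM to 10000 nM.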

Compound 4, half-maximal cytotoxic concentration: >= 200000 nM
Compound 4 was reported as a limit; the forecaster's own chance of this, stated with the estimate: 5%; middle value at least 100-fold (2.00 log units) from the limit.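

In this assay compound 4 gives >= 200000 nM, which is a limit of the assay and not a number. A carbamoyl group on this amine nitrogen therefore does not by itself go with the low numbers of compound 1 and compound 2, and compound 4 goes against that pattern: phenyl in place of 1-methylethenyl on a carbonyl carbon gives an at least 160-fold higher number from compound 1 to compound 4 (2.22 log units; beyond the scatter), and benzoyl in place of (ethoxycarbonyl)methyl on an amide-type nitrogen gives an at least 15-fold higher number from compound 2 to compound 4 (1.18 log units; beyond the scatter). Both steps are large, so what sits at the far end of the carbamoyl counts for at least as much here as the carbamoyl itself, while the step from compound 3 to compound 4 cannot be read.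

From the compounds shown here alone, how far the true values of compound 3 and compound 4 lie beyond the limit remains unknown, so the two cannot be ordered. The compounds shown also leave open whether it is the aromatic ring that matters on the carbonyl carbon, which a saturated cyclohexyl ring or a small methyl group there could test, and whether an amine on the phenyl ring would bring the numbers back down.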